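The source may report more compounds than this note shows. Statements on the series, on what has been measured and on what is new or still open speak of the compounds shown alone.

Of the compounds shown here, three share one core and have been measured. In an assay for inhibition of 15-hydroxyprostaglandin dehydrogenase [NAD(+)] (Homo sapiens), read by fluorescence, with a stated time of 15 min, in the presence of a further agent that is not named here (a lower number here means a stronger inhibitor, a higher number a weaker inhibitor), compound 1 `CCCC[S+]([O-])c1sc2nc(-c3nccs3)cc(-c3ccc(C(=O)OC)cc3)c2c1N` gives 15.1 nM, compound 2 `CCCC[S+]([O-])c1sc2nc(-c3nccs3)cc(-c3ccc(CN)cc3)c2c1N` gives 11.5 nM, and compound 3 `CCCC[S+]([O-])c1sc2nc(-c3nccs3)cc(-c3ccc(CCO)cc3)c2c1N` gives 2.9 nM. The steps among them are a 1.3-fold lower number from compound 1 to compound 2 (0.12 log units; within the scatter), a 5.2-fold lower number from compound 1 to compound 3 (0.72 log units; beyond the scatter) and a 4.0-fold lower number from compound 2 to compound 3 (0.60 log units; beyond the scatter), so compound 3 has the lowest number of the three and is the strongest inhibitor here, its nearest neighbour being compound 2.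

Compound 4 `CCCC[S+]([O-])c1sc2nc(-c3nccs3)cc(-c3cnc(C)[nH]3)c2c1N` differs from compound 3 in one place: 2-methyl-1H-imidazol-5-yl in place of 4-(2-hydroxyethyl)phenyl on an aromatic carbon. For the measured compounds named here, none of the measured steps bears directly on this change, since each of them only swaps a group attached to the six-membered aromatic ring of carbon only, whereas here that whole ring leaves and a 2-methyl-1H-imidazol-5-yl group enters. Going by the values given here, the measured steps show only that changes at this position moved the number modestly. The expectation is therefore uncertain; a step of a 4.1-fold higher number from compound 3 to compound 4 (0.62 log units; beyond the scatter) is expected, a small to modest loss in this assay. Compound 4 is estimated at 12 nM, within a range of 3 nM to 50 nM.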

Compound 4, half-maximal inhibitory concentration: 2.3 nM
Compound 4: middle estimate off by 5.2-fold (0.72 log units), on the high side; the whole stated range lies above it.
By their numbers in this assay, from the lowest: compounds 4 and 3 (each within the scatter of the next); then compounds 2 and 1 (each within the scatter of the next).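

In this assay, the 4-(2-hydroxyethyl)phenyl group can be replaced by the 2-methyl-1H-imidazol-5-yl group, which has fewer heavy atoms and a five-membered ring with 2 hetero atoms, without a change beyond the scatter (a 1.3-fold lower number from compound 3 to compound 4 (0.10 log units; within the scatter)), so a six-membered aromatic ring of carbon only is not needed here for a low number. Against the other two phenyl groups, the same imidazolyl group gives a step beyond the scatter, both from 4-(aminomethyl)phenyl (a 5.0-fold lower number from compound 2 to compound 4 (0.70 log units; beyond the scatter)) and from 4-(methoxycarbonyl)phenyl (a 6.6-fold lower number from compound 1 to compound 4 (0.82 log units; beyond the scatter)). Nothing measured here explains these results.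

The compounds shown leave open what the methyl group on the imidazole contributes, which the unsubstituted 1H-imidazol-5-yl group would test. They also leave open how a pyridin-3-yl ring would fare at this position.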